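The source may report more compounds than this note shows. Statements on the series, on what has been measured and on what is new or still open speak of the compounds shown alone.

Measured compounds:
- compound 1, `COc1ccc(CN2C(=O)C(=O)c3cc(-c4ccc(Cl)cc4)ccc32)cc1`: 380 nM
- compound 2, `COc1ccc(CN2C(=O)C(=O)c3cc(-c4ccc(C#N)cc4)ccc32)cc1`: 890 nM

Both compounds were tested in a functional assay on HepG2 cells (Homo sapiens) for antiproliferative activity, read by MTT assay, with a stated time of 48 h; on this read-out higher numbers stand for weaker inhibition and lower numbers for stronger inhibition. Among the compounds with values here, compound 2 gives 890 nM, the highest of the two numbers measured; its nearest neighbour is compound 1, and the only measured step, a 2.3-fold higher number from compound 1 to compound 2 (0.37 log units; beyond the scatter), is a modest one.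

Compound 3, `COc1ccc(CN2C(=O)C(=O)c3cc(-c4ccncc4)ccc32)cc1`, has not been measured. It differs from compound 2 in one place: pyridin-4-yl in place of 4-cyanophenyl on an aromatic carbon.

Within the data shown here, the single measured step does bear on this change, since it also alters the group at the same position, and it shows that the read-out moves only modestly when that group is changed. Among the measured compounds shown here, no measured pair, however, swaps the whole aryl group for a pyridin-4-yl, so there is no direct precedent for the step from compound 2 to compound 3. On that basis a small step is expected, most likely within the scatter or only slightly beyond it, in either direction, giving an expected 1.1-fold higher number from compound 2 to compound 3 (0.05 log units; within the scatter).

Compound 3 is therefore estimated at 1000 nM, with a range from 400 nM to 2500 nM.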

Compound 3, half-maximal inhibitory concentration: > 10000 nM
Compound 3: only a limit was reported; the forecaster's own chance of this, stated with the estimate: 5%; middle value at least 10-fold (1.00 log units) from the limit.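

Compound 3 carries no exact number in this assay, only a limit of the assay: the limit of > 10000 nM in this assay, at which 1 of the 3 values shown sits. Changing only the group carried on the phenyl ring gave a 2.3-fold higher number from compound 1 to compound 2 (0.37 log units; beyond the scatter), whereas pyridin-4-yl in place of 4-cyanophenyl gives an at least 11-fold higher number from compound 2 to compound 3 (1.05 log units; beyond the scatter), and pyridin-4-yl in place of 4-chlorophenyl gives an at least 26-fold higher number from compound 1 to compound 3 (1.42 log units; beyond the scatter). Among these three compounds, this position on the shared core therefore proves far more sensitive than the first pair suggested: exchanging the whole aryl group has a large effect on the read-out, while exchanging chloro for cyano has only a modest one.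

The three compounds leave open whether the large step comes from the nitrogen in the ring or from the loss of the chloro or cyano substituent, since pyridin-4-yl differs from both aryl groups in both respects. On these data alone, a plain phenyl group, a pyridin-3-yl group or a 4-aminophenyl group at the same place could help separate these two changes, and the true size of both large steps stays unknown beyond the limit.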